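The source may report more compounds than this note shows. Statements on the series, on what has been measured and on what is new or still open speak of the compounds shown alone.

Measured so far in a functional assay on HepG2 cells (Homo sapiens) for antiproliferative activity, read by MTT assay, with a stated time of 48 h; on this read-out lower numbers stand for stronger inhibition and higher numbers for weaker inhibition:
- compound 1 `O=C(CN1CCCCC1)Nc1ccc2ncnc(Nc3cccc(Cl)c3)c2c1` gives 12000 nM as a number
- compound 2 `O=C(CN1CCCC1)Nc1ccc2ncnc(Nc3cccc(Br)c3)c2c1` gives > 100000 nM as a limit

Compound 2 therefore has no number of its own, because its reading of > 100000 nM is a limit and nothing more. Compound 3 `O=C(CN1CCCCC1)Nc1ccc2ncnc(Nc3cccc(Br)c3)c2c1` differs from compound 2 in one place, where piperidin-1-yl takes the place of pyrrolidin-1-yl on a saturated chain carbon bound to a carbonyl carbon (piperidin-1-yl in place of pyrrolidin-1-yl on a saturated chain carbon bound to a carbonyl carbon). Compound 1 also carries piperidin-1-yl and gives 12000 nM in this assay as a measured number, so a number is expected for compound 3 too, although one compound is thin support. A large move toward lower numbers, meaning stronger inhibition, is expected in this assay, with an at least 5.0-fold lower number from compound 2 to compound 3 (0.69 log units; beyond the scatter) as the estimated step. For compound 3 the estimated value is 20000 nM, with an expected range from 6000 nM to 70000 nM in this measurement.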

Compound 3, half-maximal inhibitory concentration: 16000 nM
Compound 3: middle estimate off by 1.3-fold (0.10 log units), on the high side; the measured number falls inside the stated range.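

In this assay, the ring on the saturated chain carbon bound to a carbonyl carbon proves to matter: piperidin-1-yl in place of pyrrolidin-1-yl gives an at least 6.2-fold lower number from compound 2 to compound 3 (0.79 log units; beyond the scatter). Going by these compounds, the true size of that step stays unknown because compound 2 has only a limit and no number of its own: the limit of > 100000 nM in this assay, at which 1 of the 3 values shown sits. Bromo in place of chloro on an aromatic carbon gives a 1.3-fold higher number from compound 1 to compound 3 (0.12 log units; within the scatter), so with piperidin-1-yl present, chloro and bromo cannot be told apart in this measurement.

The compounds shown leave open whether the ring change would have a similar effect with chloro, as this comparison rests on a single bromo pair. They also leave open how a morpholin-4-yl ring or an open-chain dimethylamino group would read on that same saturated chain carbon.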